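The compounds below may be only part of what the source reports. "The series", "measured", "known", "first", "only" and "open" are said of these compounds alone.

Three compounds have been measured in a functional assay on CHO cells for activation of 5-hydroxytryptamine receptor 1D (Homo sapiens), read by GTPgammaS binding; a lower number here means that less compound is needed, a higher number that more compound is needed for the effect:

Compound 1, `c1ccc(CN2CCN(CCCc3c[nH]c4ccc(-n5cnnc5)cc34)CC2)nc1`: 0.3 nM
Compound 2, `c1c[nH]c(CN2CCN(CCCc3c[nH]c4ccc(-n5cnnc5)cc34)CC2)n1`: 2 nM
Compound 3, `CC(=O)Nc1ccc(CN2CCN(CCCc3c[nH]c4ccc(-n5cnnc5)cc34)CC2)cc1`: 6.1 nM

Compound 1 gives the lowest number of the three, so the least of it is needed; compound 2 stands nearest, with a 6.7-fold higher number from compound 1 to compound 2 (0.82 log units; beyond the scatter), and compound 3 furthest, with a 20-fold higher number from compound 1 to compound 3 (1.31 log units; beyond the scatter). Compound 2 and compound 3 differ by a 3.1-fold higher number from compound 2 to compound 3 (0.48 log units; beyond the scatter).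

The unmeasured compound 4 is `c1cnc(N2CCN(CCCc3c[nH]c4ccc(-n5cnnc5)cc34)CC2)nc1`. Compared with compound 1 the change is pyrimidin-2-yl in place of (pyridin-2-yl)methyl on an amine nitrogen in a ring. The measured steps each swapped the ring on the saturated chain carbon while keeping that carbon; here the carbon is removed and a six-membered aromatic ring with two hetero atoms sits directly on the ring nitrogen. Within the data shown here, no measured step matches this exactly. Both measured changes from compound 1 raised the number, so the expected direction is upward, and an expected step of a modest size, a 10-fold higher number from compound 1 to compound 4 (1.00 log units; beyond the scatter), seems reasonable. For compound 4 the estimated value in this assay is 3 nM, expected to fall between 0.6 nM and 15 nM.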

Compound 4, half-maximal effective concentration: 0.6 nM
The estimate for compound 4 lay 5.0-fold (0.70 log units) above the measured number; the range from low to high includes it.
By their numbers in this assay, from the lowest: compounds 1 and 4 (each within the scatter of the next); then compound 2; then compound 3.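

Taking out the saturated chain carbon and placing pyrimidin-2-yl directly on the amine nitrogen in a ring does not move the number beyond the scatter in this assay, with a 2.0-fold higher number from compound 1 to compound 4 (0.30 log units; within the scatter). At this position, then, the aromatic ring need not be held on a chain carbon, at least for this pair. Compound 4 also stays clearly apart from the other two, with a 3.3-fold lower number from compound 2 to compound 4 (0.52 log units; beyond the scatter) and a 10-fold lower number from compound 3 to compound 4 (1.01 log units; beyond the scatter), so the direct attachment matches the low number of compound 1 rather than those of compound 2 and compound 3.

Nothing shown explains why this change leaves the number so close to that of compound 1. On these data alone, because the step changes both the ring and its attachment, the part played by each stays open, and a (pyrimidin-2-yl)methyl group on the same nitrogen would separate the two.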